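Methanesulfonamide in place of pyrazole on the fused core

This account rests on a few compounds, and the source may have more. Where it says the series, first, only, none or still open, it means among the compounds named here.

Measured so far:
compound 1, `Cc1n[nH]cc1-c1cccc2c1CCC2c1ncc[nH]1`, gives 902 nM in a functional assay on CHO cells for agonist activity at Alpha-1B adrenergic receptor (Homo sapiens), read by FLIPR and calcium flux; a higher number here means that more compound is needed for the effect, a lower number that less compound is needed.
compound 2, `Cc1c(OCC2=NCCN2)ccc(Cl)c1NS(C)(=O)=O`, reports only a limit, > 10000 nM.
compound 3, `CS(=O)(=O)Nc1c(Cl)ccc2c1CCCC2c1ncc[nH]1`, likewise reports only a limit, > 10000 nM.

Within the data shown here, compound 1 is the only member of the set with a number; the other two sit at the limit of > 10000 nM in this assay, at which 2 of the 3 values shown sit. Compound 4, `CS(=O)(=O)Nc1cccc2c1CCC2c1ncc[nH]1`, differs from compound 1 in one place: methanesulfonamido in place of 3-methyl-1H-pyrazol-4-yl on an aromatic carbon. Among the measured compounds shown here, no step between measured compounds covers this exchange. Compound 3, which also carries methanesulfonamido on its core, shows only the limit > 10000 nM. On that showing, compound 4 is expected to move toward weaker activity, by an 8.9-fold higher number from compound 1 to compound 4 (0.95 log units; beyond the scatter). The estimate for compound 4 is 8000 nM, with a range from 2000 nM to 30000 nM.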

Compound 4, half-maximal effective concentration: > 10000 nM
Compound 4: no number, only a limit (the forecaster's own chance of this, stated with the estimate: 45%); middle value at least 1.2-fold (0.09 log units) away from the limit.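

Compound 4 reports only a limit in this assay, > 10000 nM. Among these compounds, this gives the first one-place comparison: methanesulfonamido in place of 3-methyl-1H-pyrazol-4-yl on this aromatic carbon produces an at least 11-fold higher number from compound 1 to compound 4 (1.04 log units; beyond the scatter). Compound 1 thus remains the only compound with a number: the limit of > 10000 nM in this assay, at which 3 of the 4 values shown sit.

From the compounds shown here alone, how far compound 4 lies past its limit remains open. Also open, going by these compounds, is whether a phenyl ring, a pyridine ring or a primary amine on this carbon would give a measurable number.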